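This account rests on a few compounds, and the source may have more. Where it says the series, first, only, none or still open, it means among the compounds named here.

Compound 1 `CN1CCN(c2ccc(Nc3nc(-c4cccc(NC(=O)c5cccc(F)c5)c4)sc3C(=O)O)cc2)CC1` and compound 2 `CN1CCN(c2ccc(Nc3nc(-c4cccc(NC(=O)c5ccccc5F)c4)sc3C(=O)O)cc2)CC1` share one core and differ only in the change (2-fluorophenyl in place of 3-fluorophenyl on a carbonyl carbon). In a functional assay on Raji cells (Homo sapiens) for antiproliferative activity, read by CCK-8 assay, with a stated time of 72 h (a lower number here means a stronger inhibitor, a higher number a weaker inhibitor), compound 1 gives 35100 nM, and compound 2 gives 13900 nM, so that change made a 2.5-fold lower number from compound 1 to compound 2 (0.40 log units; beyond the scatter). Compound 3 `CN1CCN(c2ccc(Nc3nc(-c4cccc(NC(=O)c5cccc(F)c5)c4)sc3C(N)=O)cc2)CC1` differs from compound 1 by amino in place of hydroxy on a carbonyl carbon; in this assay compound 3 stands as "not determined" (no result reported), so it has no reported result. Compound 4 `CN1CCN(c2ccc(Nc3nc(-c4cccc(NC(=O)c5ccccc5F)c4)sc3C(N)=O)cc2)CC1` stands to compound 3 as compound 2 stands to compound 1: the change is 2-fluorophenyl in place of 3-fluorophenyl on a carbonyl carbon, the same change at the same place. With no number for compound 3, any expectation for compound 4 can rest only on compound 2, whose result in this assay is 13900 nM, together with the carboxy-to-carbamoyl difference, whose size is not measured here. Compound 4 is therefore estimated at 15000 nM in this assay, with a wide expected range from 3500 nM to 60000 nM.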

Compound 4, half-maximal inhibitory concentration: 3270 nM
Beside the measured number, compound 4's estimate is 4.6-fold (0.66 log units) above it; measured number below the stated range.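

In this assay, amino in place of hydroxy on a carbonyl carbon gives a 4.3-fold lower number from compound 2 to compound 4 (0.63 log units; beyond the scatter), so the amide core carrying the 2-fluorophenyl reads lower than the matching carboxylic acid. Whether the fluorine change seen in the acid core, a 2.5-fold lower number from compound 1 to compound 2 (0.40 log units; beyond the scatter), carries over to the amide core is not shown: with no result for compound 3, the steps from compound 3 to compound 4 and from compound 1 to compound 3 cannot be read. Nothing measured here bears on why the number drops.

Left open is how a methyl ester or a nitrile would read in place of the carboxylic acid or amide. Also open, going by these compounds, is how a 2-chlorophenyl would read in place of the 2-fluorophenyl.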